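This account rests on a few compounds, and the source may have more. Where it says the series, first, only, none or still open, it means among the compounds named here.

Compound 1 `Cc1ccccc1S(=O)(=O)c1ccc(CNC(=O)c2cc3cnccc3[nH]2)cc1`: 48%
Compound 2 `O=C(NCc1ccc(S(=O)(=O)c2ccccc2)cc1)c1nc2ccncc2s1`: 68%
Compound 3 `O=C(NCc1ccc(S(=O)(=O)c2ccccc2)cc1)c1ccc2cnccc2c1`: 31%

In an ADME assay on microsomes from liver (Homo sapiens) for metabolic stability, read by LC-MS, with a stated time of 30 min, tested at 1 uM (on this read-out higher numbers stand for a more stable compound and lower numbers for a less stable compound), compound 1 stands in the middle of these three, with gaps beyond the usual scatter to both others. Compound 4 `O=C(NCc1ccc(S(=O)(=O)c2ccc(F)cc2)cc1)c1cc2cnccc2[nH]1` has not been measured yet. It keeps the core of compound 1 but carries 4-fluorophenyl in place of 2-methylphenyl on a sulfonyl sulfur. Going by the values given here, no pair of measured compounds shows this change on its own, so any forecast is uncertain. A modest rise, slightly beyond the scatter, is expected, and the estimated step is a number 12 percentage points higher from compound 1 to compound 4 (beyond the scatter). For compound 4 the estimated value is 60%, with an expected range from 40% to 78%.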

Compound 4, percent of the compound remaining: 91%
Beside the measured number, compound 4's estimate is 31 percentage points below it, and the stated range ends below it.
By their numbers in this assay, from the lowest: compound 3; then compound 1; then compound 2; then compound 4.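

Within this assay, putting 4-fluorophenyl in place of 2-methylphenyl on a sulfonyl sulfur, with the rest of the molecule unchanged, gives a number 43 percentage points higher from compound 1 to compound 4 (beyond the scatter). Going by these compounds alone, the earlier compounds offered no pair differing in one place, so this is the first direct sign that the group on the sulfonyl sulfur can strongly shift this read-out. Nothing available accounts for the size of this step.

Still open, as far as these compounds go, is whether the rise follows the loss of the methyl or the arrival of the fluorine, which plain phenyl on this core would separate. Also open, from the compounds shown here alone, is how 4-chlorophenyl or 4-methoxyphenyl on the sulfonyl sulfur would compare.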